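The source may report more compounds than this note shows. Statements on the series, on what has been measured and on what is new or still open speak of the compounds shown alone.

Measured so far in a functional assay on DU-145 cells (Homo sapiens) for inhibition, read by CCK-8 assay, with a stated time of 72 h (on this read-out higher numbers stand for weaker inhibition and lower numbers for stronger inhibition), are two compounds:

Compound 1 `O=C(/C=C/c1cccnc1)NCCCc1ccc(S(=O)(=O)Nc2ccccc2)cc1` gives > 10000 nM as a limit of the assay
Compound 2 `Cc1ccc(C)c(NS(=O)(=O)c2cccc(CCCCCCNC(=O)/C=C/c3cccnc3)c2)c1` gives 7.48 nM as a measured number

Compound 1 thus has a limit and not a number. Going by the values given here, compound 2 at 7.48 nM is the only compound here with a true number in this assay to measure against. Compound 3 `O=C(/C=C/c1cccnc1)NCCCCCCc1cccc(S(=O)(=O)Nc2ccc(C(F)(F)F)cc2)c1` has not yet been measured. It carries 4-(trifluoromethyl)phenyl in place of 2,5-dimethylphenyl on a sulfonamide nitrogen, a change counted as 4-(trifluoromethyl)phenyl in place of 2,5-dimethylphenyl on a sulfonamide nitrogen in full. Among the compounds with values here, no measured pair shows what such a swap does, so the expectation rests on compound 2 at 7.48 nM alone. A modest weakening is expected, somewhat beyond the scatter, with the expected change being a 2.7-fold higher number from compound 2 to compound 3 (0.43 log units; beyond the scatter) on this reading. For compound 3 the estimate is 20 nM as the expected value, within an expected range of 3 nM to 150 nM on repeated measurement.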

Compound 3, half-maximal inhibitory concentration: 1410 nM
For compound 3 the middle estimate is 71-fold (1.85 log units) below the measured one; measured number above the stated range.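

In this assay, the group on the sulfonamide nitrogen proves to be a highly sensitive place in this pair: 4-(trifluoromethyl)phenyl in place of 2,5-dimethylphenyl gives a 190-fold higher number from compound 2 to compound 3 (2.28 log units; beyond the scatter), a large loss of inhibition from this one change. Compound 3 still gives a true number and not a limit, so the size of this step can be read in full. Nothing measured here explains why the step is so large.

The compounds shown leave open whether the loss goes with the two methyl groups leaving or with the trifluoromethyl group entering, as both happen in this single step. A plain phenyl or a 4-methylphenyl on the same nitrogen would help separate these two parts of the change.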